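A few compounds are considered here, and "the series" means these few. Any claim that something is new, unique, unknown or untested is made for them only; others in the source may bear on it.

Compound 3 `CCC(C)(C)/N=C(\NC#N)Nc1cc(F)cc(Br)c1` gives 0.016 uM in a functional assay with Cavia porcellus as the target (on this read-out higher numbers stand for an effect only at larger amounts of compound and lower numbers for an effect already at smaller amounts), the lower of the two numbers obtained, although its nearest neighbour lies within the scatter. That neighbour, compound 2 `CCC(C)(C)/N=C(\NC#N)Nc1cc(F)cc(Cl)c1`, gives 0.032 uM. Compound 1 `CCC(CC)(CC)/N=C(\NC#N)Nc1cc(Cl)cc(C#N)c1` reaches only a limit of this assay, > 1 uM. Compound 4 `CCC(C)(C)/N=C(\NC#N)Nc1cc(Br)cc(C#N)c1` differs from compound 3 by cyano in place of fluoro on an aromatic carbon. Going by the values given here, the only measured step, a 2.0-fold lower number from compound 2 to compound 3 (0.30 log units; within the scatter), exchanged one halogen for another and stayed within the scatter; no measured step swaps fluoro for cyano. Compound 1 also carries a cyano group, but it differs from compound 4 in more than one place, so it offers only a hint that a cyano group goes with a weaker effect. For compound 4 a weaker effect is expected, a 6.3-fold higher number from compound 3 to compound 4 (0.80 log units; beyond the scatter), with an estimate of 0.1 uM spanning 0.02 uM to 1 uM.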

Compound 4, concentration for half-maximal effect: 0.011 uM
The estimate for compound 4 lay 9.1-fold (0.96 log units) above the measured number; measured number below the stated range.
By their numbers in this assay, from the lowest: compounds 4, 3 and 2 (each within the scatter of the next, the first and the last beyond it). At a limit, above all of these: compound 1.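

Cyano in place of fluoro on this aromatic carbon gives a 1.5-fold lower number from compound 3 to compound 4 (0.16 log units; within the scatter) in this assay, so here the two groups cannot be told apart on this read-out. Going by these compounds alone, until now the only cyano compound was compound 1, which differs in more than one place, and this one-place change does not bear out the hint from it. Nothing shown explains why the number stays within the scatter.

Going by these compounds, whether this position also accepts an amine, a carboxylic acid or a methoxy group stays open. So does whether cyano behaves the same way with chloro in place of bromo.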